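The compounds below may be only part of what the source reports. "The series", "measured", "known", "first", "only" and "open" are said of these compounds alone.

Of the compounds shown here, three with a shared core have been tested in an assay on isolated protein for binding affinity to Bile acid receptor (Homo sapiens), read by FRET; on this read-out higher numbers stand for an effect only at larger amounts of compound and lower numbers for an effect already at smaller amounts. Compound 1 `CC(C)c1onc(-c2c(Cl)cccc2Cl)c1COc1ccc2cc(-c3ccc(C(=O)O)cc3)ccc2c1` gives 440 nM. Compound 2 `CC(C)c1onc(-c2c(Cl)cccc2Cl)c1COc1ccc2c(ccn2Cc2cccc(C(=O)O)c2)c1` gives 320 nM, which is the lowest of the three numbers, although its gap to compound 1 and its gap to compound 3 both lie within the usual scatter of repeated measurements. Compound 3 `CC(C)c1onc(-c2c(Cl)cccc2Cl)c1COc1ccc2c(Cc3cccc(C(=O)O)c3)c[nH]c2c1` gives 590 nM.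

Compound 4 `CC(C)c1onc(-c2c(Cl)cccc2Cl)c1COc1ccc2c(ccn2C(=O)c2cccc(C(=O)O)c2)c1` has not yet been measured in this assay. It differs from compound 2 in a single place: (3-carboxyphenyl)carbonyl in place of 3-carboxybenzyl on an aromatic nitrogen. Within the data shown here, no measured pair in this set differs in just this way, so there is no comparable step to draw on. With only the three measured values as a guide, the expected step is a 1.6-fold higher number from compound 2 to compound 4 (0.19 log units; within the scatter), a shift that could go either way and that is not expected to reach clearly beyond the scatter. On that basis compound 4 is estimated at 500 nM, with a plausible range from 150 nM to 1700 nM.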

Compound 4, half-maximal effective concentration: 150 nM
Compound 4: middle estimate off by 3.3-fold (0.52 log units), on the high side; measured number inside the range.
By their numbers in this assay, from the lowest: compound 4; then compounds 2, 1 and 3 (each within the scatter of the next).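

Among these compounds, at the aromatic nitrogen of the shared core, putting (3-carboxyphenyl)carbonyl in place of 3-carboxybenzyl gives a 2.1-fold lower number from compound 2 to compound 4 (0.33 log units; beyond the scatter) in this assay, the only step here that can be read, and a modest one. This shows that the number responds to a single change at this position, and that the group linking this nitrogen to the carbon ring can carry a carbonyl without a rise in the number; the entering group has 2 hydrogen-bond acceptors against 1 in the group it replaces. Nothing available explains why the number falls.

Going by these compounds, whether a sulfonyl group or a longer chain in place of that carbonyl would move the number further remains open. So does whether a tetrazole could stand in for the carboxylic acid on this group.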